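The compounds below may be only part of what the source reports. "The series", "measured", "known", "first", "only" and "open" are said of these compounds alone.

In an ADME assay on microsomes from liver (Canis lupus familiaris) for metabolic stability (on this read-out higher numbers stand for a longer-lived compound and lower numbers for a shorter-lived compound), compound 1 `N#Cc1ccc(-c2nc(NCCNc3ccc([N+](=O)[O-])c(N)n3)ncc2-c2ncc[nH]2)cc1` gives > 0.5 h as its result, which is a limit and not a number. Compound 2 `Nc1nc(NCCNc2ncc(-c3ncc[nH]3)c(-c3ccccc3Br)n2)ccc1[N+](=O)[O-]` gives > 0.5 h as its result, again a limit. Compound 3 `Nc1nc(NCCNc2ncc(-c3ncc[nH]3)c(-c3cc(F)ccc3F)n2)ccc1[N+](=O)[O-]` gives > 0.5 h as its result, also a limit. Compound 3 therefore has no exact place in the series, and all that can be said of it rests on the limit of > 0.5 h in this assay, at which 3 of the 3 values shown sit, alone.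

Compound 4 `Nc1nc(NCCNc2ncc(-c3ncc[nH]3)c(-c3ccc(F)cc3Br)n2)ccc1[N+](=O)[O-]` differs from compound 3 by one group: 2-bromo-4-fluorophenyl in place of 2,5-difluorophenyl on an aromatic carbon and the new group, 2-bromo-4-fluorophenyl, takes the place of 2,5-difluorophenyl on an aromatic carbon. Compound 2 carries 2-bromophenyl, the group closest to the incoming one, so a step that the two limits leave unreadable from compound 2 to compound 3 is the most relevant comparison. The other two comparisons are a step that the two limits leave unreadable from compound 1 to compound 2 and a step that the two limits leave unreadable from compound 1 to compound 3 and none of the three has a readable size. No step beyond the usual scatter can be forecast from them, and no direction either.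

The estimated step is a step that the limit leaves unreadable from compound 3 to compound 4 and this expectation carries no preferred direction. Compound 4 is expected to be reported as a limit too because the limit of > 0.5 h in this assay, at which 3 of the 3 values shown sit, covers compound 3 and both of its measured neighbours. For compound 4 the estimated half-life is 0.8 h with an expected range from 0.4 h to 1.6 h if a number is obtained at all.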

Compound 4, half-life: > 0.5 h
Compound 4: a limit, no number (the forecaster's own chance of this, stated with the estimate: 85%); the middle value does not contradict the limit.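

In this assay compound 4 gives > 0.5 h, which is a limit and not a number. Going by these compounds alone, no step between compound 4 and compound 1, compound 2 or compound 3 can be read, because all four results are limits: the limit of > 0.5 h in this assay, at which 4 of the 4 values shown sit. The compounds shown leave open the actual half-life of each one, and whether exchanging the groups on the shared core changes it at all.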